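From difluorophenyl to trifluoromethylphenyl on the shared core

This account rests on a few compounds, and the source may have more. Where it says the series, first, only, none or still open, it means among the compounds named here.

Compound 1, `O=C(O)c1ccc2nc(N3CCC(OCc4c(-c5c(Cl)cccc5Cl)noc4C4CC4)CC3)sc2c1`: 118%
Compound 2, `O=C(O)c1ccc2nc(N3CCC(OCc4c(-c5c(F)cccc5F)noc4C4CC4)CC3)sc2c1`: 92%

Within the data shown here, in an assay on HEK-293T cells for agonist activity at Bile acid receptor (Homo sapiens), read by a luciferase reporter, with a stated time of 24 h (on this read-out lower numbers stand for smaller maximal responses and higher numbers for larger maximal responses), compound 2 gives the lower of the two numbers; the single measured step is a number 26 percentage points lower from compound 1 to compound 2 (beyond the scatter). Compound 3, `O=C(O)c1ccc2nc(N3CCC(OCc4c(-c5ccccc5C(F)(F)F)noc4C4CC4)CC3)sc2c1`, is reached by the change (2-(trifluoromethyl)phenyl in place of 2,6-difluorophenyl on an aromatic carbon). Among the measured compounds shown here, only that one step bears on this change, and it concerns a different pair of groups, so it sets no direction here. Compound 3 is therefore expected to land near compound 2, with an expected step of a number 8 percentage points higher from compound 2 to compound 3 (within the scatter) inside the scatter. The estimate for compound 3 is 100%, with a range from 75% to 125%.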

Compound 3, largest response reached (reported as efficacy), in percent of the reference or control that the assay uses in the Bile acid receptor assay: 103%
Compound 3: middle estimate off by 3 percentage points, on the low side, and the stated range covers the measured number.
By their numbers in the Bile acid receptor assay, from the lowest: compound 2; then compound 3; then compound 1.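

In the Bile acid receptor assay, the 2-(trifluoromethyl)phenyl group gives a response that falls inside the gap between the two earlier groups, with a number 11 percentage points higher from compound 2 to compound 3 (beyond the scatter) and a number 15 percentage points lower from compound 1 to compound 3 (beyond the scatter) on the shared core, so this position also accepts a phenyl ring with a single group on it. In a physicochemical assay for solubility, in simulated intestinal fluid, at pH 6.8 (on this read-out lower numbers stand for lower solubility and higher numbers for higher solubility), compound 2 gives 169000 nM and compound 3 gives 131000 nM, and a 1.3-fold lower number from compound 2 to compound 3 (0.11 log units; within the scatter) stays inside the usual scatter of that read-out. Nothing available explains these differences.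

The compounds shown leave open how a nitrile or a methoxy group in place of the trifluoromethyl on this phenyl ring would read in either assay.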